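The source may hold more compounds than are shown below. What is called first, only, known or untested is meant among the compounds shown, and "the series" means these compounds.

Compound 1, `O=c1[nH]cnc2c1c(-c1cccs1)cn2[C@@H]1O[C@H](CO)[C@@H](O)[C@H]1O`: in a functional assay on K562 cells (Homo sapiens), read by MTT assay, with a stated time of 72 h (on this read-out lower numbers stand for stronger inhibition and higher numbers for weaker inhibition), compound 1 gives > 20000 nM, which is a limit of the assay.
Compound 2, `O=c1[nH]cnc2c1c(-c1ccsc1)cn2[C@@H]1O[C@H](CO)[C@@H](O)[C@H]1O`: in this assay compound 2 gives > 20000 nM, again a limit.
Compound 3, `O=c1[nH]cnc2c1c(-c1ccco1)cn2[C@@H]1O[C@H](CO)[C@@H](O)[C@H]1O`: in this assay compound 3 gives 17800 nM.

For the measured compounds named here, compound 3 thus carries the only number measured; the other two values sit at the limit of > 20000 nM in this assay, at which 2 of the 3 values shown sit. The step of an at least 1.1-fold lower number from compound 1 to compound 3 (0.05 log units; that floor lies within the scatter) and the step of an at least 1.1-fold lower number from compound 2 to compound 3 (0.05 log units; that floor lies within the scatter) are floors only, and a step that the two limits leave unreadable from compound 1 to compound 2 cannot be read.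

Compound 4, `Nc1nc2c(c(-c3ccco3)cn2[C@@H]2O[C@H](CO)[C@@H](O)[C@H]2O)c(=O)[nH]1`, differs from compound 3 by amino in place of hydrogen on an aromatic carbon. Going by the values given here, none of the measured steps touches this change, since all three vary the five-membered ring. No step beyond the scatter is therefore expected in this assay, and compound 4 is estimated at 12000 nM, spanning 3000 nM to 40000 nM, an expected step of a 1.5-fold lower number from compound 3 to compound 4 (0.17 log units; within the scatter).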

Compound 4, half-maximal inhibitory concentration: > 20000 nM
Compound 4: only a limit was reported; the forecaster's own chance of this, stated with the estimate: 35%; middle value at least 1.6-fold (0.22 log units) from the limit.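

Compound 4 alone among these compounds changes the carbon between two ring nitrogen atoms, and amino in place of hydrogen there gives an at least 1.1-fold higher number from compound 3 to compound 4 (0.05 log units; that floor lies within the scatter). For the compounds shown here, this change therefore returns no measured number, and compound 3 remains the only compound with one in this assay. Compound 4 joins the others at the limit: the limit of > 20000 nM in this assay, at which 3 of the 4 values shown sit.

The true size of this step and the steps among compounds at the limit cannot be read. As far as these compounds go, whether methylamino or dimethylamino on the same carbon would give a measured number remains open.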